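Same aryl swap carried into a second hydrazide core

The source may hold more compounds than are shown below. What is called first, only, known or untested is meant among the compounds shown, and "the series" means these compounds.

Measured so far in a physicochemical assay for lipophilicity; a higher number here means a more lipophilic compound, a lower number a more polar compound:
compound 1 `N=C(N)Nc1cccc(C(=O)NNC(=O)NC(CC(=O)O)c2ccc(OC(F)(F)F)cc2)c1`: 2.23
compound 2 `N=C(N)Nc1cccc(C(=O)NNC(=O)NC(CC(=O)O)c2cccc3ccccc23)c1`: 1.7
compound 3 `O=C(O)CC(NC(=O)NNC(=O)CCCCNc1ccccn1)c1ccc(OC(F)(F)F)cc1`: 3.17

Compound 3 stands highest of the three; compound 2 stands lowest. The change from compound 1 to compound 2 is naphthalen-1-yl in place of 4-(trifluoromethoxy)phenyl on a saturated chain carbon bound to an amide-type nitrogen and a saturated chain carbon. In this assay that change made a step of a number 0.53 log units lower from compound 1 to compound 2 (beyond the scatter).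

Compound 4 `O=C(O)CC(NC(=O)NNC(=O)CCCCNc1ccccn1)c1cccc2ccccc12` is not yet measured. It differs from compound 3 by naphthalen-1-yl in place of 4-(trifluoromethoxy)phenyl on a saturated chain carbon bound to an amide-type nitrogen and a saturated chain carbon, the same change at the same place, now on the core of compound 3. The two cores differ by a group of 11 heavy atoms (9 carbon, 2 nitrogen; one six-membered aromatic ring with 1 hetero atom) in place of a group of 10 heavy atoms (7 carbon, 3 nitrogen; one six-membered aromatic ring of carbon only), on a carbonyl carbon, a difference that brought a number 0.94 log units higher from compound 1 to compound 3 (beyond the scatter).

Among the measured compounds shown here, the expectation for compound 4 rests on the single earlier step of a number 0.53 log units lower from compound 1 to compound 2 (beyond the scatter), with no second example to test it. The expected step is a number 0.53 log units lower from compound 3 to compound 4 (beyond the scatter). Compound 4 is therefore estimated at 2.64, likely between 2.2 and 3.1.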

Compound 4, partition coefficient: 2.64
Compound 4: middle estimate and measured number agree at the digits printed; the range from low to high includes it.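

In this assay, naphthalen-1-yl in place of 4-(trifluoromethoxy)phenyl gave a number 0.53 log units lower from compound 3 to compound 4 (beyond the scatter) and so matched in size the earlier a number 0.53 log units lower from compound 1 to compound 2 (beyond the scatter) on the other core. Read the other way, the core change gave a number 0.94 log units higher from compound 2 to compound 4 (beyond the scatter) and matched a number 0.94 log units higher from compound 1 to compound 3 (beyond the scatter) so that, in these four compounds, each change kept its size whichever form of the other was present. This rests on two cores and one aryl swap, so it does not show that the change would carry to further cores, and nothing measured here offers an explanation for the match.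

The compounds shown leave open whether the step holds with another group on the carbonyl carbon, such as a longer alkyl chain ending in a primary amine. They also leave open whether it holds when an ester stands in place of the carboxylic acid.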